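The source may hold more compounds than are shown below. What is called first, only, known or untested is meant among the compounds shown, and "the series" means these compounds.

Working notes on the series, read in a functional assay (aorta) with Oryctolagus cuniculus as the target; a lower number here means tighter binding, a higher number weaker binding. Compound 1 `Cc1ccnc2c1nc(C)n2Cc1ccc(-c2ccccc2C(=O)O)cc1` gives 50.1 nM, compound 2 `Cc1ccnc2c1nc(C(C)C)n2Cc1ccc(-c2ccccc2C(=O)O)cc1` gives 31.6 nM, and compound 3 `COCc1nc2c(C)ccnc2n1Cc1ccc(-c2ccccc2C(=O)O)cc1` gives 79.4 nM. Compound 3 therefore stands within the scatter of one neighbour, a 1.6-fold higher number from compound 1 to compound 3 (0.20 log units; within the scatter), and beyond it for the other, a 2.5-fold higher number from compound 2 to compound 3 (0.40 log units; beyond the scatter).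

Compound 4 `C/C=C/c1nc2c(C)ccnc2n1Cc1ccc(-c2ccccc2C(=O)O)cc1` changes one group of compound 3: prop-1-en-1-yl in place of methoxymethyl on an aromatic carbon.

For the measured compounds named here, no measured compound carries prop-1-en-1-yl, so only indirect guidance exists. The closest step is a 2.5-fold higher number from compound 2 to compound 3 (0.40 log units; beyond the scatter), where methoxymethyl replaced isopropyl, a modest change. The step of a 1.6-fold lower number from compound 1 to compound 2 (0.20 log units; within the scatter) shows that exchanging one carbon group for another at this place stayed within the scatter. Taken together, these suggest a small shift towards the numbers of compound 1 and compound 2 on leaving methoxymethyl, possibly none beyond the scatter.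

The expected change is a 2.0-fold lower number from compound 3 to compound 4 (0.30 log units; within the scatter). For compound 4 the estimated value in this assay is 40 nM, with an expected range of 15 nM to 100 nM.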

Compound 4, dissociation constant: 5.01 nM
Compound 4: the middle estimate sits 8.0-fold (0.90 log units) above what was measured, and the stated range ends above it.
By their numbers in this assay, from the lowest: compound 4; then compounds 2, 1 and 3 (each within the scatter of the next, the first and the last beyond it).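

In this assay, for the compounds shown here, this position, on an aromatic carbon between two ring nitrogen atoms, proves far more responsive than the earlier compounds showed: prop-1-en-1-yl gives a 16-fold lower number from compound 3 to compound 4 (1.20 log units; beyond the scatter) and also a 6.3-fold lower number from compound 2 to compound 4 (0.80 log units; beyond the scatter) as well as a 10-fold lower number from compound 1 to compound 4 (1.00 log units; beyond the scatter) in the same series. All three steps lie beyond the scatter, so compound 4 stands apart from every earlier neighbour. Methoxymethyl and prop-1-en-1-yl have the same count of heavy atoms, so that count alone does not separate compound 3 from compound 4.

Whether the double bond itself matters remains open, as the compounds shown include neither a saturated propyl chain nor the other alkene geometry, nor a longer alkenyl chain. The data at hand offer no measurement that accounts for this gain.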